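The compounds below may be only part of what the source reports. "The series", "measured", "known", "first", "only" and "open" are said of these compounds alone.

Measured compounds, in a functional assay on U-373MG ATCC cells (Homo sapiens) for inhibition, read by colorimetric assay and MTT assay, with a stated time of 72 h; on this read-out higher numbers stand for weaker inhibition and lower numbers for stronger inhibition:
- Compound 1 `Cn1c2cnc1OCCCCCCCCOc1cc3ccccc3cc1-2`: 24000 nM
- Compound 2 `C=CCCCCOc1ccccc1-c1cnc(OC)n1C`: > 100000 nM (a limit, not a number)
- Compound 3 `Cn1c(-c2ccccc2O)cnc1S(=O)(=O)c1ccccc1`: > 100000 nM (a limit, not a number)

Only compound 1 has a true number in this assay. The rest of the set is defined by the limit of > 100000 nM in this assay, at which 2 of the 3 values shown sit. Compound 3 stands at that limit, so its position is a bound and the real size of any step from it cannot be read.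

Compound 4 `C=CCCOc1ccccc1-c1cnc(S(=O)(=O)c2ccccc2)n1C` carries but-3-en-1-yl in place of hydrogen on an oxygen on an aromatic ring, which turns hydroxy into (but-3-en-1-yl)oxy (but-3-en-1-yl in place of hydrogen on an oxygen on an aromatic ring).

Among the measured compounds shown here, no measured pair isolates this change. Compound 2 also carries an unsaturated ether chain and remains at the limit > 100000 nM. A large gain is therefore not expected, and a reading at the limit again is quite possible. The expected change is at most a small move towards stronger inhibition, estimated as an at least 1.4-fold lower number from compound 3 to compound 4 (0.15 log units; that floor lies within the scatter). The estimate for compound 4 is 70000 nM, with an expected range from 25000 nM to 150000 nM.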

Compound 4, half-maximal inhibitory concentration: > 100000 nM
Compound 4: a limit, no number; the forecaster's own chance of this, stated with the estimate: 60%; at least 1.4-fold (0.15 log units) between middle value and limit.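

Among the compounds shown here, compound 3 and compound 4 both read as limits, not numbers, so no step between them can be read: the limit of > 100000 nM in this assay, at which 3 of the 4 values shown sit.

The compounds shown leave open whether (but-3-en-1-yl)oxy in place of hydroxy changes inhibition at all.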